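This account rests on a few compounds, and the source may have more. Where it says the series, first, only, none or still open, it means among the compounds named here.

Working notes on ether variants of the shared core, read in a physicochemical assay for lipophilicity; on this read-out lower numbers stand for lower lipophilicity and higher numbers for higher lipophilicity: compound 1 `CC(C)(C)C#Cc1cc(N(C(=O)[C@H]2CC[C@H](C)CC2)[C@H]2CC[C@H](OC3COC3)CC2)c(C(=O)O)s1` gives 2.6, compound 2 `CC(C)(C)C#Cc1cc(N(C(=O)[C@H]2CC[C@H](C)CC2)[C@H]2CC[C@H](OC3CCOC3)CC2)c(C(=O)O)s1` gives 2.3, and compound 3 `CC(C)(C)C#Cc1cc(N(C(=O)[C@H]2CC[C@H](C)CC2)[C@H]2CC[C@H](Oc3ccc(=O)[nH]n3)CC2)c(C(=O)O)s1` gives 2. Compound 3 stands at the low end of these numbers. Compound 4 `CC(C)(C)C#Cc1cc(N(C(=O)[C@H]2CC[C@H](C)CC2)[C@H]2CC[C@H](Oc3ccccn3)CC2)c(C(=O)O)s1` differs from it by a group of 6 heavy atoms (5 carbon, 1 nitrogen; one six-membered aromatic ring with 1 hetero atom) in place of a group of 7 heavy atoms (4 carbon, 2 nitrogen, 1 oxygen; one six-membered aromatic ring with 2 hetero atoms), on an oxygen on a saturated carbon, so pyridin-2-yl enters on an oxygen on a saturated carbon. Among the compounds with values here, two measured steps bear on this, since both bring in the group now leaving: a number 0.60 log units lower from compound 1 to compound 3 (beyond the scatter) and a number 0.30 log units lower from compound 2 to compound 3 (within the scatter). Neither involves pyridin-2-yl, so they suggest a direction more than a size. The expected step is a number 1.00 log units higher from compound 3 to compound 4 (beyond the scatter), upward and beyond the scatter. Compound 4 is estimated at 3, with an expected range of 2.5 to 3.5.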

Compound 4, distribution coefficient: 3
For compound 4 middle estimate and measured number coincide at the digits printed; the measured number falls inside the stated range.
By their numbers in this assay, from the lowest: compounds 3, 2 and 1 (each within the scatter of the next, the first and the last beyond it); then compound 4.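

Pyridin-2-yl on an oxygen on a saturated carbon gives the first upward steps at this position, against oxetan-3-yl (a number 0.40 log units higher from compound 1 to compound 4 (beyond the scatter)) and oxolan-3-yl (a number 0.70 log units higher from compound 2 to compound 4 (beyond the scatter)). Compound 3 and compound 4 both carry a six-membered aromatic ring on this oxygen, yet their step is the largest shown (a number 1.00 log units higher from compound 3 to compound 4 (beyond the scatter)), so the presence of such a ring does not alone set the number. No supporting data explain these steps.

From the compounds shown here alone, a phenyl or pyrimidin-2-yl group on this oxygen remains open in this assay, as does the effect of an amine on the pyridin-2-yl ring.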